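Removing One Large Group from Compound 2

The compounds below may be only part of what the source reports. "The series", "measured", "known", "first", "only" and "open" are said of these compounds alone.

Two measured compounds frame this comparison. Compound 1 `O=C(CCCCC[C@H](NC(=O)C1C(=O)NCC1c1ccccc1)C(=O)Nc1ccccc1)NO` and compound 2 `Cc1ccc(NC(=O)[C@H](CCCCCC(=O)NO)NC(=O)[C@H]2CCC(=O)N2)cc1` share a long chain that ends in a hydroxamic acid, and both were tested in an assay on isolated protein for inhibition of histone deacetylase 11 (Homo sapiens), read by fluorescence; on this read-out higher numbers stand for weaker inhibition and lower numbers for stronger inhibition. In this assay compound 1 gives 70 nM. In this assay compound 2 gives 127 nM, the higher of the two numbers, yet the gap to compound 1 lies within the usual scatter of repeated measurements, so the two cannot be ranked. Compound 3 `Cc1ccc(NC(=O)CCCCCCC(=O)NO)cc1` is compound 2 with one change: hydrogen in place of ((5-oxopyrrolidin-2-yl)carbonyl)amino on a saturated chain carbon bound to a carbonyl carbon and a saturated chain carbon. For the measured compounds named here, a sizeable piece of the molecule disappears, and no measured pair here shows what that piece contributes. The step from compound 2 to compound 3 is expected to be a clear move towards weaker inhibition, of about a 12-fold higher number from compound 2 to compound 3 (1.07 log units; beyond the scatter), beyond the scatter. Compound 3 is therefore estimated at 1500 nM in this assay, with a likely range from 300 nM to 8000 nM.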

Compound 3, half-maximal inhibitory concentration: 78.6 nM
Compound 3: the middle estimate sits 19-fold (1.28 log units) above what was measured; the measured number lies below the stated range.
By their numbers in this assay, from the lowest: compounds 1, 3 and 2 (each within the scatter of the next).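

In this assay the step is a 1.6-fold lower number from compound 2 to compound 3 (0.21 log units; within the scatter) when the ((5-oxopyrrolidin-2-yl)carbonyl)amino group gives way to hydrogen on this saturated chain carbon. A piece of 9 heavy atoms, with its five-membered non-aromatic ring and its defined stereocentre, can therefore go from this position without a readable loss of inhibition, and compound 3 holds up without it. Nothing at hand explains why so large a change leaves the number within the scatter.

Still open, from the compounds shown here alone, is whether any smaller group on this carbon, such as an amine or a carboxylic acid, would move the number beyond the scatter. Also open, going by these compounds, is what a longer chain leading to the hydroxamic acid would do in compound 3.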